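Lengthening the Side Chain from Methyl to Isobutyl

The source may report more compounds than this note shows. Statements on the series, on what has been measured and on what is new or still open speak of the compounds shown alone.

Measured so far:
compound 1, `CC(C)[C@H](NCCC1OCC(C)(C)CO1)C(=O)N[C@H]1C(O)O[C@H](CO)[C@@H](O)[C@@H]1O`, 85.1%
compound 2, `C[C@H](NCCC1OCC(C)(C)CO1)C(=O)N[C@H]1C(O)O[C@H](CO)[C@@H](O)[C@@H]1O`, 86.8%

Both compounds were tested in a functional assay on the whole organism (Ear, strain ICR) for inhibition, with Mus musculus as the target, with stated times of 30 min and 2 h, at a dose of 10 umol/kg by the oral route; a lower number here means less inhibition, a higher number more inhibition at the dose given (going by the name of the read-out). In this assay compound 1 gives 85.1% and compound 2 gives 86.8%. Among the compounds with values here, compound 2 thus holds the higher of the two numbers, but the only step leading to it, a number 1.7 percentage points higher from compound 1 to compound 2 (within the scatter), lies within the scatter, so the two compounds cannot be told apart.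

Compound 3, `CC(C)C[C@H](NCCC1OCC(C)(C)CO1)C(=O)N[C@H]1C(O)O[C@H](CO)[C@@H](O)[C@@H]1O`, carries isopropyl in place of hydrogen on a saturated chain carbon, two bonds along the chain from an amine nitrogen and a carbonyl carbon. Within the data shown here, the one measured step that bears on this, a number 1.7 percentage points higher from compound 1 to compound 2 (within the scatter), also changed the size of the group on the saturated chain carbon bound to an amine nitrogen and a carbonyl carbon, trading isopropyl for methyl, and it made no difference beyond the scatter. Growing that group again, now from methyl to isobutyl, gives no reason to expect anything else.

Compound 3 is therefore expected to give 85%, with a range from 72% to 95%. The step this estimate means, a number 1.8 percentage points lower from compound 2 to compound 3 (within the scatter), is expected to stay within the scatter.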

Compound 3, a percentage reported as inhibition, in the whole organism at one dose (the size of the read-out at that dose, not a potency): 81.8%
Beside the measured number, compound 3's estimate is 3.2 percentage points above it, and the stated range covers the measured number.
By their numbers in this assay, from the lowest: compounds 3, 1 and 2 (each within the scatter of the next).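

Isobutyl on the saturated chain carbon bound to an amine nitrogen and a carbonyl carbon now gives a third side chain at this position, and in this assay the numbers show a number 5 percentage points lower from compound 2 to compound 3 (within the scatter) and a number 3.3 percentage points lower from compound 1 to compound 3 (within the scatter). Neither step leaves the scatter, so compound 1, compound 2 and compound 3 cannot be told apart in this read-out, and methyl, isopropyl and isobutyl all give numbers of the same size at this dose. No other measurement accompanies these numbers, so nothing here explains why this change leaves the read-out within the scatter.

The compounds shown leave open whether a different kind of group at this position, such as a carboxylic acid, an amine or a phenyl ring, would move the number beyond the scatter. As far as these compounds go, a reading at one dose gives the size of the effect and not a potency, so it also remains open whether these three compounds would separate at a lower dose.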